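Mirror-Image Aminodiol: Expectation for the Enantiomer of Compound 1

This account rests on a few compounds, and the source may have more. Where it says the series, first, only, none or still open, it means among the compounds named here.

Measured compounds:
compound 1 `CCCCCCCCCCCCCCCCCC[C@@H](N)[C@@H](O)CO`, 10600 nM in a functional assay on Lewis lung carcinoma cells for inhibition, with Lewis lung carcinoma cell line (Mus musculus) as the target; on this read-out higher numbers stand for weaker inhibition and lower numbers for stronger inhibition
compound 2 `CCCCCCCCCCCCCC[C@H](NC(=O)OC(C)(C)C)[C@H](O)CO`, 24200 nM in this assay
compound 3 `CCCCCCCCCCCCCC[C@@H](N)[C@@H](O)CO`, 1870 nM in this assay

Compound 1 stands second highest of the three numbers in this assay; compound 2 lies nearest, and compound 3 furthest with a 5.7-fold lower number from compound 1 to compound 3 (0.75 log units; beyond the scatter). Compound 4 `CCCCCCCCCCCCCCCCCC[C@H](N)[C@H](O)CO` is its mirror image: the two compounds have the same atoms and bonds and differ only in configuration as drawn: 2 of 2 stereo elements differ (all stereocentres are inverted: mirror images); a stereocentre at a saturated chain carbon is drawn R in compound 1 and S in compound 4; a stereocentre at a saturated chain carbon is drawn R in compound 1 and S in compound 4. For the measured compounds named here, no measured step involves a change of configuration alone, so none of the steps bears on it; the only recorded step, a 5.7-fold lower number from compound 1 to compound 3 (0.75 log units; beyond the scatter), concerns chain length. With nothing to support a shift, compound 4 is expected to give 10000 nM (range 3000 nM to 40000 nM), an expected step of a 1.1-fold lower number from compound 1 to compound 4 (0.03 log units; within the scatter), not beyond the scatter.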

Compound 4, half-maximal inhibitory concentration: 3470 nM
For compound 4 the middle estimate is 2.9-fold (0.46 log units) above the measured one; measured number inside the range.
By their numbers in this assay, from the lowest: compounds 3 and 4 (each within the scatter of the next); then compound 1; then compound 2.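

Inverting both stereocentres gives a 3.1-fold lower number from compound 1 to compound 4 (0.48 log units; beyond the scatter) in this assay, so this read-out tells the mirror images of the aminodiol apart, which the earlier step on chain length could not show. The shift can be assigned to configuration and to nothing else, because no atom or bond separates the pair: the fact that compounds 1 and 4 differ only in the configuration as drawn

Which of the two stereocentres carries the shift remains open. So does whether the same inversion would matter with a longer chain, or with a carboxylic acid in place of the amine.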